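The compounds below may be only part of what the source reports. "The series", "measured", "known", "first", "only" and "open" are said of these compounds alone.

Compound 1 `Cc1ccc(OCC(=O)N(Cc2cccs2)C2CCCCC2)cc1`: 40000 nM
Compound 2 `CCN(Cc1cccs1)C(=O)COc1ccc(OC)cc1`: 120 nM
Compound 3 `CCN(Cc1cccs1)C(=O)c1cc2cc(C)ccc2[nH]1`: 2010 nM

All three were tested in an assay on HEK293 cells for agonist activity at transient receptor potential cation channel subfamily M member 8 (Homo sapiens), read by fluorescence and calcium flux, with a stated time of 15 min; a higher number here means that more compound is needed for the effect, a lower number that less compound is needed. Compound 1 stands highest of the three: compound 3 sits nearest, with a number far lower, and compound 2 furthest, lower still, both gaps beyond the scatter. Compound 4 `CCC(C)N(Cc1cccs1)C(=O)COc1ccc(C)cc1` has not been measured yet. It differs from compound 1 in one place: sec-butyl in place of cyclohexyl on an amide-type nitrogen. For the measured compounds named here, no pair of measured compounds differs in a single place, so no measured step guides this change directly. Still, compound 4 is expected to need less compound than compound 1, a step of a 27-fold lower number from compound 1 to compound 4 (1.43 log units; beyond the scatter) in this assay, beyond the scatter, partly because compound 2 gives 120 nM. Compound 4 is therefore estimated at 1500 nM, with a range from 200 nM to 10000 nM.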

Compound 4, half-maximal effective concentration: 2000 nM
Compound 4: the middle estimate sits 1.3-fold (0.12 log units) below what was measured, and the stated range covers the measured number.
By their numbers in this assay, from the lowest: compound 2; then compounds 4 and 3 (each within the scatter of the next); then compound 1.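

In this assay, for the compounds shown here, sec-butyl in place of cyclohexyl on the amide-type nitrogen gives a 20-fold lower number from compound 1 to compound 4 (1.30 log units; beyond the scatter), the first step here that changes a single place. It shows that the group at this position matters: going from a six-carbon ring to a four-carbon group without a ring moves the number well beyond the scatter. No measurement here explains this shift. The compounds shown leave open whether the ring or the carbon count drives the step: a straight hexyl chain or a cyclobutyl ring at this position would help separate the two.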